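Swapping the Ring on a Thiocarbonyl Carbon

The source may report more compounds than this note shows. Statements on the series, on what has been measured and on what is new or still open speak of the compounds shown alone.

Measured so far in a functional assay on DU-145 cells (Homo sapiens) for inhibition, read by MTT assay, with stated times of 18 h and 4 h; on this read-out lower numbers stand for stronger inhibition and higher numbers for weaker inhibition:
compound 1 `CCCCCCCCCCCCCCCCOP(=O)(O)OCCSC(=S)N1CCCCCC1` gives 17600 nM
compound 2 `CCCCCCCCOP(=O)(O)OCCSC(=S)N1CCCC1` gives 47100 nM
compound 3 `CCCCCCCCCCOP(=O)(O)OCCSC(=S)N1CCCCCC1` gives 24000 nM

All three compounds share a long saturated chain joined through a phosphate to a short linker that ends in a dithiocarbamate, whose thiocarbonyl carbon carries a saturated nitrogen ring. Compound 3 lies within the scatter of both of its neighbours: compound 1 is its nearest and compound 2 its furthest, and neither gap is beyond the scatter.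

Compound 4 `CCCCCCCCCCOP(=O)(O)OCCSC(=S)N1CCCC1` is compound 3 with a different ring: pyrrolidin-1-yl in place of azepan-1-yl on a thiocarbonyl carbon

Among the measured compounds shown here, the only measured step that changes a single place, a 1.4-fold higher number from compound 1 to compound 3 (0.13 log units; within the scatter), concerns the chain rather than the ring, so it says nothing direct about this swap. Compound 2 already carries the pyrrolidin-1-yl ring but also a shorter chain than compound 3, so the two differ in two places; their values show a modest gap, and the chain step from compound 1 to compound 3 suggests chain length alone moves little. The ring swap is therefore expected to shift the number only modestly, if at all, towards weaker inhibition, as a 1.6-fold higher number from compound 3 to compound 4 (0.20 log units; within the scatter).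

Compound 4 is estimated at 38000 nM, within 15000 nM to 95000 nM.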

Compound 4, half-maximal inhibitory concentration: 46100 nM
The estimate for compound 4 lay 1.2-fold (0.08 log units) below the measured number; the range from low to high includes it.
By their numbers in this assay, from the lowest: compounds 1, 3, 4 and 2 (each within the scatter of the next, the first and the last beyond it).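

In this assay, among the compounds shown here, the step from azepan-1-yl to pyrrolidin-1-yl on a thiocarbonyl carbon is the first direct look at the ring at this position, and it comes out as a 1.9-fold higher number from compound 3 to compound 4 (0.28 log units; within the scatter). Going from a seven-membered to a five-membered ring therefore produces no difference that can be told apart from the ordinary spread of repeated measurements, at least with this chain. With the pyrrolidin-1-yl ring held fixed, ethyl in place of hydrogen on a saturated chain carbon, eight bonds along the chain from an oxygen on an unsaturated carbon, gives a 1.0-fold lower number from compound 2 to compound 4 (0.01 log units; within the scatter), so this chain change also stays inside that spread, as the earlier chain step on the azepan-1-yl compounds did.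

Nothing further is available that could explain these numbers.

The compounds shown leave open whether a ring of a different kind on the thiocarbonyl carbon, such as morpholin-4-yl, or an open diethylamino group would give a step beyond the scatter. They also leave open whether the pyrrolidin-1-yl ring would give a similar number on a longer chain.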